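Isobutyl Ether in Place of Benzyl on the Carbamate Series

The compounds below may be only part of what the source reports. "The series", "measured", "known", "first", "only" and "open" are said of these compounds alone.

Compound 3 `Cc1cc(NC(=O)OC(C)(C)C)nn1Cc1cc(Cl)ccc1OCc1ccccc1` gives 25.1 nM in an assay on CHO-K1 cells for displacement of a labelled ligand from prostaglandin E2 receptor EP1 subtype (Homo sapiens); on this read-out lower numbers stand for stronger inhibition and higher numbers for weaker inhibition. Within the data shown here, that puts compound 3 level with compound 2 `Cc1cc(NC(=O)C2CCCC2)nn1Cc1cc(Cl)ccc1OCC(C)C`, which gives 25.1 nM, and within the scatter of compound 1 `Cc1cc(NC(=O)C2CCCCC2)nn1Cc1cc(Cl)ccc1OCC(C)C`, which gives 31.6 nM; no pair among the three is separated by more than the usual scatter. Among the measured compounds shown here, the only step between measured neighbours is a 1.3-fold lower number from compound 1 to compound 2 (0.10 log units; within the scatter), a change on the carbonyl side of the molecule rather than on the ether, so it speaks only indirectly to what follows. The change from compound 3 to compound 4 `Cc1cc(NC(=O)OC(C)(C)C)nn1Cc1cc(Cl)ccc1OCC(C)C` is isopropyl in place of phenyl on a saturated chain carbon bound to an oxygen on an aromatic ring. For the measured compounds named here, no measured pair isolates this ether change, but compound 1 and compound 2 already carry the isobutoxy group, and compound 1 sits at 31.6 nM while compound 2 sits at 25.1 nM, close to compound 3. Compound 4 is therefore expected at 25 nM, with a range from 10 nM to 63 nM. The expected step is a 1.0-fold lower number from compound 3 to compound 4 (0.00 log units; within the scatter), nothing beyond the scatter.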

Compound 4, half-maximal inhibitory concentration: 31.6 nM
Compound 4: middle estimate off by 1.3-fold (0.10 log units), on the low side, within the range that was stated.
By their numbers in this assay, from the lowest: compounds 2, 3, 1 and 4 (each within the scatter of the next).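

In this assay, a 1.3-fold higher number from compound 3 to compound 4 (0.10 log units; within the scatter), so on the carbamate series benzyloxy and isobutoxy cannot be told apart, even though the phenyl ring leaves and no ring enters. With isobutoxy held in place, the carbonyl side now gives a matching picture: a 1.3-fold higher number from compound 2 to compound 4 (0.10 log units; within the scatter), and no change at the digits printed from compound 1 to compound 4 (within the scatter), which puts tert-butoxy on a carbonyl carbon within the scatter of both cyclopentyl and cyclohexyl. Nothing available accounts for why these exchanges leave the read-out within the scatter.

The compounds shown leave open whether this tolerance on the saturated chain carbon bound to an oxygen on an aromatic ring extends to a longer chain or to a chain carrying a carboxylic acid. They also leave open whether an amine on the carbonyl carbon in place of tert-butoxy would stay within the same scatter.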